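Swapping the Amide Group on a Carbonyl Carbon

A few compounds are considered here, and "the series" means these few. Any claim that something is new, unique, unknown or untested is made for them only; others in the source may bear on it.

Values in an ADME assay on HeLa cells (Homo sapiens) for cytotoxicity, read by MTT assay; a higher number here means a weaker inhibitor, a lower number a stronger inhibitor:
- Compound 1 `COc1ccc(C[C@H]2COC(=O)[C@@H]2Cc2ccc(OCC(=O)N3CCCCC3)c(OC)c2)cc1OC`: 293000 nM
- Compound 2 `COc1ccc(C[C@H]2COC(=O)[C@@H]2Cc2ccc(OC(=O)CCC(=O)N3CCCC3)c(OC)c2)cc1OC`: 201000 nM
- Compound 3 `COc1ccc(C[C@H]2COC(=O)[C@@H]2Cc2ccc(OCC(=O)N3CCCC3)c(OC)c2)cc1OC`: >= 600000 nM, a limit of the assay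

Compound 2 and compound 1 lie within the scatter of each other, as a 1.5-fold lower number from compound 1 to compound 2 (0.16 log units; within the scatter) shows. Compound 4 `COC(=O)[C@H](CCSC)NC(=O)CCC(=O)Oc1ccc(C[C@H]2C(=O)OC[C@@H]2Cc2ccc(OC)c(OC)c2)cc1OC` differs from compound 2 in one group: (1-(methoxycarbonyl)-3-(methylsulfanyl)propyl)amino in place of pyrrolidin-1-yl on a carbonyl carbon. In words, (1-(methoxycarbonyl)-3-(methylsulfanyl)propyl)amino stands in place of pyrrolidin-1-yl on a carbonyl carbon. The closest measured swap on a carbonyl carbon is an at least 2.0-fold higher number from compound 1 to compound 3 (0.31 log units; beyond the scatter), with pyrrolidin-1-yl in place of piperidin-1-yl. That swap rests on a limit and involves a very different group, so no step beyond the scatter is expected in this assay. The estimated step is a 1.0-fold lower number from compound 2 to compound 4 (0.00 log units; within the scatter). For compound 4 the expected value is 200000 nM, with an estimated range from 80000 nM to 500000 nM.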

Compound 4, half-maximal inhibitory concentration: 199000 nM
Estimate against measurement, compound 4: 1.0-fold (0.00 log units) above; the measured number falls inside the stated range.
By their numbers in this assay, from the lowest: compounds 4, 2 and 1 (each within the scatter of the next). At a limit, above all of these: compound 3.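

On the carbonyl carbon whose other neighbour is a saturated chain carbon, replacing pyrrolidin-1-yl with (1-(methoxycarbonyl)-3-(methylsulfanyl)propyl)amino gives a 1.0-fold lower number from compound 2 to compound 4 (0.00 log units; within the scatter) in this assay. The earlier swap on a carbonyl carbon exchanged one ring for another, whereas this one puts an open chain with a hydrogen-bond donor and a defined stereocentre in place of the ring, and the two numbers stay within the scatter. Compound 4 gives a number, not a limit, unlike the one value that is a limit: the limit of >= 600000 nM in this assay, at which 1 of the 4 values shown sits.

As far as these compounds go, whether the number would hold with a carboxylic acid in place of the methoxycarbonyl group, or with an amine in place of the methylsulfanyl group, remains open.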